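A few compounds are considered here, and "the series" means these few. Any claim that something is new, unique, unknown or untested is made for them only; others in the source may bear on it.

In a functional assay on HeLa cells (Homo sapiens) for inhibition, read by CCK-8 assay, with a stated time of 48 h (on this read-out higher numbers stand for weaker inhibition and lower numbers for stronger inhibition), two compounds with the same core have been measured so far. Compound 1 `COc1cc(-c2ccnc3cc(-c4ccc(Cl)cc4)nn23)cc(OC)c1OC`, which carries 4-chlorophenyl, gives 1490 nM. Compound 2 `COc1cc(-c2ccnc3cc(-c4ccc5c(ccn5C)c4)nn23)cc(OC)c1OC`, which carries 1-methyl-1H-indol-5-yl in its place, gives 19 nM, the lower of the two numbers and so the stronger inhibition. Among the compounds with values here, that swap is the only measured step: a 78-fold lower number from compound 1 to compound 2 (1.89 log units; beyond the scatter), a large change beyond the usual scatter. It shows that this one place can move the number a long way.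

Compound 3 `COc1cc(-c2ccnc3cc(-c4cn(C)c5ccccc45)nn23)cc(OC)c1OC` has the same atoms as compound 2, joined differently: 1-methyl-1H-indol-3-yl in place of 1-methyl-1H-indol-5-yl on an aromatic carbon. Within the data shown here, no measured pair tests such a shift in attachment, so the step from 4-chlorophenyl bears on it only loosely. That step replaced one group with a quite different one, while this change keeps the atom counts the same, so a smaller step is expected. Among the measured compounds shown here, compound 2, at 19 nM, holds the lowest number so far, so the expected direction is toward weaker inhibition. The estimated step is a 5.3-fold higher number from compound 2 to compound 3 (0.72 log units; beyond the scatter). The estimate for compound 3 is 100 nM, with an expected range from 20 nM to 500 nM.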

Compound 3, half-maximal inhibitory concentration: 399 nM
Beside the measured number, compound 3's estimate is 4.0-fold (0.60 log units) below it; measured number inside the range.
By their numbers in this assay, from the lowest: compound 2; then compound 3; then compound 1.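

In this assay, changing only the point of attachment, with 1-methyl-1H-indol-3-yl in place of 1-methyl-1H-indol-5-yl, gives a 21-fold higher number from compound 2 to compound 3 (1.32 log units; beyond the scatter). At this position, then, the number depends on how the group is joined as well as on what it contains, since the two groups have the same atoms, rings, donors and acceptors. The other new step is a 3.7-fold lower number from compound 1 to compound 3 (0.57 log units; beyond the scatter): 1-methyl-1H-indol-3-yl still gives stronger inhibition than 4-chlorophenyl, but this modest step shows that the large gain seen with 1-methyl-1H-indol-5-yl does not simply come with any 1-methylindole joined here, and no measured evidence is available to explain the difference between the two attachments.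

The compounds shown leave open how other attachment points would behave, such as in 1-methyl-1H-indol-6-yl or 1-methyl-1H-indol-4-yl. They also leave open what part the methyl plays, which 1H-indol-5-yl or 1-ethyl-1H-indol-5-yl could test, and whether an amine or a carboxylic acid on the 1-methyl-1H-indol-5-yl group would be tolerated.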